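Replacing 4-butylpiperazin-1-yl with piperidin-1-yl on the shared core

This account rests on a few compounds, and the source may have more. Where it says the series, first, only, none or still open, it means among the compounds named here.

- compound 1 `CN1CCN(CCCCn2c3c(c4ccccc42)C(=O)c2c[n+]([O-])c4ccccc4c2C3=O)CC1` gives 30 nM
- compound 2 `CCCCN1CCN(CCCCn2c3c(c4ccccc42)C(=O)c2c[n+]([O-])c4ccccc4c2C3=O)CC1` gives 2150 nM

In a functional assay on A-375 cells (Homo sapiens) for cytotoxicity, read by MTT assay, with a stated time of 72 h (a higher number here means a weaker inhibitor, a lower number a stronger inhibitor), compound 2 stands highest of the two, at 2150 nM. Compound 3 `O=C1c2c[n+]([O-])c3ccccc3c2C(=O)c2c1c1ccccc1n2CCCCN1CCCCC1` has piperidin-1-yl in place of 4-butylpiperazin-1-yl on a saturated chain carbon, four bonds along the chain from an aromatic nitrogen. Among the measured compounds shown here, the one measured step that bears on this is large, a 72-fold higher number from compound 1 to compound 2 (1.86 log units; beyond the scatter), and it went with lengthening the group on the ring. Compound 3 lacks the butyl group, so much of that step is expected to be reversed. The expected step is a 14-fold lower number from compound 2 to compound 3 (1.16 log units; beyond the scatter), towards a stronger inhibitor. For compound 3 the estimated value is 150 nM, with a range of 30 nM to 800 nM.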

Compound 3, half-maximal inhibitory concentration: 190 nM
Beside the measured number, compound 3's estimate is 1.3-fold (0.10 log units) below it; measured number inside the range.
By their numbers in this assay, from the lowest: compound 1; then compound 3; then compound 2.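

In this assay, piperidin-1-yl in place of 4-butylpiperazin-1-yl gives an 11-fold lower number from compound 2 to compound 3 (1.05 log units; beyond the scatter) at this place, so the large loss seen with the butyl group is not a loss for every ring here. Yet piperidin-1-yl in place of 4-methylpiperazin-1-yl gives a 6.3-fold higher number from compound 1 to compound 3 (0.80 log units; beyond the scatter) and does not reach compound 1, so the identity of the ring still counts at this place. Nothing measured here explains either step.

Open, from the compounds shown here alone, is whether pyrrolidin-1-yl or morpholin-4-yl would come closer to compound 1. Also open, going by these compounds, is how unsubstituted piperazin-1-yl would compare with both rings.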